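Swapping hydroxy for amino on a stilbene-like scaffold

The compounds below may be only part of what the source reports. "The series", "measured", "known", "first", "only" and "open" are said of these compounds alone.

Three compounds have been measured in a functional assay on HT-29 cells (Homo sapiens) for inhibition, read by MTT assay, with a stated time of 2 days; a higher number here means a weaker inhibitor, a lower number a stronger inhibitor:

Compound 1 `COc1ccccc1/C=C/c1cccc(O)c1` gives 17 ug/mL.
Compound 2 `COc1cccc(/C=C/c2cccc(O)c2)c1` gives 11.5 ug/mL.
Compound 3 `COc1ccccc1/C=C/c1cccc(N)c1` gives 25.3 ug/mL.

Compound 3 differs from compound 1 by one change, (amino in place of hydroxy on an aromatic carbon), and that change gave a 1.5-fold higher number from compound 1 to compound 3 (0.17 log units; within the scatter). Compound 4 `COc1cccc(/C=C/c2cccc(N)c2)c1` has not yet been measured; it differs from compound 2 by amino in place of hydroxy on an aromatic carbon, the same change in the same place, but on the core of compound 2. The difference between the two cores is not broken down here. Compounds 1 and 2 give values within the scatter of each other, so nothing separates the two cores so far.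

The expectation for compound 4 rests on compound 2, whose value in this assay is 11.5 ug/mL, and on the step seen from compound 1 to compound 3: the estimated step from compound 2 to compound 4 in this assay is a 1.5-fold higher number from compound 2 to compound 4 (0.17 log units; within the scatter), a change of similar size. Compound 4 is therefore estimated to give 17 ug/mL in this assay, expected to fall between 9 ug/mL and 33 ug/mL.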

Compound 4, half-maximal inhibitory concentration: 19.6 ug/mL
Compound 4: middle estimate off by 1.2-fold (0.06 log units), on the low side; the measured number falls inside the stated range.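

In this assay, putting amino in place of hydroxy on the core of compound 2 gave a 1.7-fold higher number from compound 2 to compound 4 (0.23 log units; within the scatter). Set beside the same change on the core of compound 1, the two steps agree: the same change on two cores in this assay, a 1.5-fold higher number (0.17 log units; within the scatter) from compound 1 to compound 3 and a 1.7-fold higher number (0.23 log units; within the scatter) from compound 2 to compound 4, 1.1-fold (0.06 log units) apart, within the scatter of two such steps

The change therefore carried across these two cores without any detectable difference, but each step is small enough to be lost in repeat measurements, so this does not show that amino and hydroxy truly differ here, nor that the agreement extends to other cores. The compounds shown leave open whether a carboxylic acid or a nitrile on the same aromatic carbon would give a step beyond the scatter in this assay.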